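The compounds below may be only part of what the source reports. "The series", "measured", "known", "first", "only" and "open" are said of these compounds alone.

Compound 1 is `COc1ccc(CNCc2c(OC)cc(Oc3cccc(Nc4ccccc4)c3)cc2OC)cc1` and gives 1890 nM in a functional assay on HT-29 cells (Homo sapiens) for inhibition, read by MTT assay, with a stated time of 72 h; on this read-out lower numbers stand for stronger inhibition and higher numbers for weaker inhibition.
Compound 2 is `CCN1CCN(Cc2c(OC)cc(Oc3cccc(Nc4ccccc4)c3)cc2OC)CC1`; in this assay compound 2 reaches only the limit > 20000 nM.
Compound 3 is `COc1cc(Oc2cccc(Nc3ccccc3)c2)cc(OC)c1CNC(C)C`; in this assay compound 3 likewise reaches only the limit > 20000 nM.

Compound 3 therefore stands at the limit of this assay, not at a number, and it shares that position with one other compound: the limit of > 20000 nM in this assay, at which 2 of the 3 values shown sit. Within the data shown here, the only readable steps start from compound 1. There was an at least 10-fold higher number from compound 1 to compound 3 (1.02 log units; beyond the scatter), and there was an at least 10-fold higher number from compound 1 to compound 2 (1.02 log units; beyond the scatter). Between the two limits there was a step that the two limits leave unreadable from compound 2 to compound 3.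

Compound 4 is `COc1cc(Oc2cccc(Nc3ccccc3)c2)cc(OC)c1CNCc1ccc(Br)cc1`. It differs from compound 3 in one place: 4-bromobenzyl in place of isopropyl on an amine nitrogen. This change runs the step from compound 1 to compound 3 in reverse, since a benzyl group again sits on the amine nitrogen, though with bromine rather than methoxy on the ring. On the strength of an at least 10-fold higher number from compound 1 to compound 3 (1.02 log units; beyond the scatter) a large step towards a lower number in this assay is expected, bringing compound 4 back towards the value of compound 1, with the bromine an open question. Compound 4 is thus expected to give about 2500 nM, within the range 800 nM to 10000 nM. The expected step is an at least 8.0-fold lower number from compound 3 to compound 4 (0.90 log units; beyond the scatter).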

Compound 4, half-maximal inhibitory concentration: 3060 nM
The estimate for compound 4 lay 1.2-fold (0.09 log units) below the measured number, within the range that was stated.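

In this assay, the amine nitrogen takes a benzyl group carrying bromine as readily as one carrying methoxy, with a 1.6-fold higher number from compound 1 to compound 4 (0.21 log units; within the scatter), so a readable value no longer rests on the 4-methoxybenzyl group alone. The change from isopropyl to 4-bromobenzyl gives an at least 6.5-fold lower number from compound 3 to compound 4 (0.81 log units; beyond the scatter), and (4-bromobenzyl)amino in place of 4-ethylpiperazin-1-yl gives an at least 6.5-fold lower number from compound 2 to compound 4 (0.81 log units; beyond the scatter), so among the four compounds shown, the two with a substituted benzyl group on this nitrogen have readable values and neither of the others does. Both of these steps start from a limit and not from a number, so their true size cannot be read and each is only a lower bound: the limit of > 20000 nM in this assay, at which 2 of the 4 values shown sit.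

The compounds shown leave open whether a plain benzyl group with nothing on its ring, or a phenethyl group with its longer chain, would give a value like those of compound 1 and compound 4. Isopropyl and 4-bromobenzyl differ both in size and in the aromatic ring, and a cyclohexylmethyl group on the same nitrogen would be needed to tell these two differences apart.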